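The compounds below may be only part of what the source reports. "The series", "measured", "known", "first", "only" and "open" are said of these compounds alone.

Compound 1 `CCCCCCC(CCO)n1cnc2c(NC)ncnc21`: > 50000 nM (a limit of the assay, not a number)
Compound 2 `CCCCCCCCCCCC(CCO)n1cnc2c(Cl)ncnc21`: 7590 nM
Compound 3 `CCCCCCCCCCCC(CCO)n1cnc2c(NC)ncnc21`: not yet measured

Among the compounds with values here, in a functional assay on HCT-116 cells (Homo sapiens) for antiproliferative activity, read by MTT assay, with a stated time of 48 h (on this read-out lower numbers stand for stronger inhibition and higher numbers for weaker inhibition), compound 2 gives 7590 nM, the only exact number so far. The step to compound 3 swaps one group: methylamino in place of chloro on an aromatic carbon. Compound 3 keeps the chain of compound 2. Compound 1 has a different chain but shares the methylamino group, and it gives > 50000 nM, which is a limit of the assay. That single clue points to weaker inhibition, so a moderate loss is expected in this assay. The estimated change is a 2.0-fold higher number from compound 2 to compound 3 (0.30 log units; within the scatter). Compound 3 is expected at 15000 nM, within a range of 5000 nM to 50000 nM.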

Compound 3, half-maximal inhibitory concentration: 15400 nM
Estimate against measurement, compound 3: 1.0-fold (0.01 log units) below, within the range that was stated.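

In this assay, methylamino in place of chloro on this aromatic carbon gives a 2.0-fold higher number from compound 2 to compound 3 (0.31 log units; beyond the scatter), so the swap costs only a modest amount of inhibition and leaves a measurable value. The chain matters too: pentyl in place of hydrogen on a saturated chain carbon gives an at least 3.2-fold lower number from compound 1 to compound 3 (0.51 log units; beyond the scatter). The value of compound 1 is a limit of the assay and not a number, so that step has no exact size: the limit of > 50000 nM in this assay, at which 1 of the 3 values shown sits.

From the compounds shown here alone, it remains open how a plain amino, dimethylamino or methoxy group would behave on this carbon. Also open, going by these compounds, is whether a chain longer than that of compound 3 would lower the number further.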